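Working notes: expected oral exposure of compound 3

The source may hold more compounds than are shown below. What is called first, only, known or untested is meant among the compounds shown, and "the series" means these compounds.

- compound 1 `CC(=O)c1nc([C@@H](O)[C@H](O)[C@H](O)CO)cn1C`: 10000 ng.h/mL
- compound 2 `CN(C)C(=O)c1nc([C@@H](O)[C@H](O)[C@H](O)CO)c[nH]1`: 1740 ng.h/mL

In an ADME assay on the whole organism (plasma, strain 129/SvEvBrd x C57BL/6) for pharmacokinetics, with Mus musculus as the target, at a dose of 10 mg/kg by the oral route (on this read-out lower numbers stand for lower exposure and higher numbers for higher exposure at the dose given), compound 2 gives 1740 ng.h/mL, the lower of the two values in hand. Compound 1 gives 10000 ng.h/mL, and the gap between them lies beyond the usual scatter. The next compound to be read is compound 3 `OC[C@@H](O)[C@@H](O)[C@H](O)c1c[nH]c(-c2ncon2)n1`. It differs from compound 2 in one place, with 1,2,4-oxadiazol-3-yl in place of dimethylcarbamoyl on an aromatic carbon. Going by the values given here, no measured pair shows a change at this place, so the data give no direct guide to its size. No shift beyond the scatter is therefore expected in this assay, and a small fall is the working guess. The estimated step is a 1.2-fold lower number from compound 2 to compound 3 (0.06 log units; within the scatter). For compound 3 the estimated value is 1500 ng.h/mL, with an expected range of 400 ng.h/mL to 6000 ng.h/mL.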

Compound 3, area under the concentration-time curve: 820 ng.h/mL
The estimate for compound 3 lay 1.8-fold (0.26 log units) above the measured number; the range from low to high includes it.
By their numbers in this assay, from the lowest: compound 3; then compound 2; then compound 1.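

In this assay, going by these compounds alone, 1,2,4-oxadiazol-3-yl in place of dimethylcarbamoyl on an aromatic carbon gives a 2.1-fold lower number from compound 2 to compound 3 (0.33 log units; beyond the scatter), the only step so far at this position. Exposure in this series therefore responds to the group held on this carbon, between two ring nitrogen atoms. The two groups have 5 heavy atoms each and no hydrogen-bond donors, so the change in exposure arises without a change in either count, although the step is only modest. Nothing available explains this step.

On these data alone, whether an amine or a carboxylic acid at this position would lower or raise exposure remains open. Also open, as far as these compounds go, is whether the same replacement would give a step of similar size on the core of compound 1.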